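The compounds below may be only part of what the source reports. "The series", "measured", "known", "first", "only" and "open" are said of these compounds alone.

Of the compounds shown here, three that share one core have been tested in a functional assay on HepG2 cells (Homo sapiens) for cytotoxicity, with a stated time of 24 h; a lower number here means a stronger inhibitor, a higher number a weaker inhibitor. Compound 1, `COc1ccc(C(=O)N/N=C/c2cc(I)cc(I)c2O)cc1`, gives 45200 nM; in this assay compound 2, `O=C(N/N=C/c1cc(I)cc(I)c1O)c1ccc(F)cc1`, gives 12100 nM, and compound 3, `O=C(N/N=C/c1cc(I)cc(I)c1O)c1ccc(I)cc1`, gives 31800 nM. Compound 1 thus stands at the top of these three numbers, though its gap to compound 3 is within the usual scatter and only compound 2 lies clearly lower. The next compound, compound 4, is `O=C(N/N=C/c1cc(I)cc(I)c1O)c1ccc(C(F)(F)F)cc1`. Its difference from compound 1 is trifluoromethyl in place of methoxy on an aromatic carbon. Two of the measured steps start from compound 1 and replace the same methoxy group: a 3.7-fold lower number from compound 1 to compound 2 (0.57 log units; beyond the scatter), and a 1.4-fold lower number from compound 1 to compound 3 (0.15 log units; within the scatter). So the swap to fluoro brought a modest fall, while the swap to iodo left a gap within the scatter; the third step, a 2.6-fold higher number from compound 2 to compound 3 (0.42 log units; beyond the scatter), fits the same picture. A trifluoromethyl group has no direct precedent among these compounds, so only a modest downward step or none beyond the scatter is expected, and the expected change is a 1.8-fold lower number from compound 1 to compound 4 (0.26 log units; within the scatter). In this assay compound 4 is therefore estimated at 25000 nM, with a range from 10000 nM to 60000 nM.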

Compound 4, half-maximal inhibitory concentration: 11700 nM
Compound 4: the middle estimate sits 2.1-fold (0.33 log units) above what was measured; measured number inside the range.
By their numbers in this assay, from the lowest: compounds 4 and 2 (each within the scatter of the next); then compounds 3 and 1 (each within the scatter of the next).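

In this assay, trifluoromethyl in place of methoxy gives a 3.9-fold lower number from compound 1 to compound 4 (0.59 log units; beyond the scatter), so a second replacement of methoxy on this aromatic carbon, after fluoro, now lowers the number beyond the scatter. The step to fluoro's neighbour in the ranking, a 1.0-fold lower number from compound 2 to compound 4 (0.01 log units; within the scatter), shows that trifluoromethyl and fluoro cannot be told apart here, even though they are different groups. Iodo, by contrast, is separated from trifluoromethyl by a 2.7-fold lower number from compound 3 to compound 4 (0.43 log units; beyond the scatter), so the groups tried at this place fall into two sets: fluoro and trifluoromethyl lie together at the lower numbers, while iodo in compound 3 stays within the scatter of methoxy in compound 1.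

Nothing measured here explains why the groups sort in this way. As far as these compounds go, it remains open where a different kind of group at this place, such as an amine, a carboxylic acid or a longer chain, would fall, and whether it would join either set or lie outside both.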